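This account rests on a few compounds, and the source may have more. Where it says the series, first, only, none or still open, it means among the compounds named here.

Measured compounds:
compound 1 `O=C(O)c1cc2cc([N+](=O)[O-])ccc2n1CCCc1ccccc1`: 65.5%
compound 2 `O=C(O)c1cc2cc([N+](=O)[O-])ccc2n1Cc1ccccc1`: 51.3%

In an assay on cells (Oocyte) for inhibition of pannexin-1 (Mus musculus), read by voltage clamp, tested at 50 uM, in the presence of a further agent that is not named here (on this read-out lower numbers stand for less inhibition and higher numbers for more inhibition at the one concentration tested (going by the name of the read-out)), compound 1 gives 65.5%, the higher of the two numbers measured, and compound 2 gives 51.3%. Among the measured compounds shown here, the one step available, a number 14.2 percentage points lower from compound 1 to compound 2 (beyond the scatter), runs by a phenyl in place of a phenethyl and is modest but beyond the scatter. Compound 3 `O=C(O)c1cc2cc([N+](=O)[O-])ccc2n1CCCCc1ccccc1` is not yet measured; it differs from compound 1 by benzyl in place of phenyl on a saturated chain carbon, three bonds along the chain from an aromatic nitrogen. This bears on the same group that is shortened in the step to compound 2, but here the change runs the other way, so that single step gives only indirect guidance. Compound 3 is therefore expected to remain close to compound 1, most likely within the scatter, with no strong reason to expect a drop of the size seen for compound 2. The expected step is a number 1.5 percentage points higher from compound 1 to compound 3 (within the scatter), and the estimate for compound 3 is 67%, between 50% and 82%.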

Compound 3, a percentage reported as inhibition, at one concentration (the size of the read-out at that concentration, not a potency): "not active" (no number reported)
Nothing numeric was reported for compound 3; no gap can be computed for the estimate.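

In this assay, among the compounds shown here, compound 3 is reported as not active, without a number, and no step from compound 1 to compound 3 can be read. The compounds shown leave open how far compound 3 lies from compound 1 on this read-out. No evidence shown bears on this result.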